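The source may report more compounds than this note shows. Statements on the series, on what has been measured and on what is new or still open speak of the compounds shown alone.

Of the compounds shown here, two have been measured so far in a functional assay on KM12 cells (Homo sapiens) for inhibition; a lower number here means a stronger inhibitor of growth, a higher number a weaker inhibitor of growth. Compound 1 `COc1cc(/C=C/C(=O)c2cccc(-n3cc(-c4ccccc4)[nH]c3=O)c2)ccc1O` gives 1610 nM in this assay. Compound 2 `COc1cc(/C=C/C(=O)c2cccc(-n3cc(-c4cc(OC)c(OC)c(OC)c4)[nH]c3=O)c2)cc(OC)c1OC` gives 1120 nM in this assay. Compound 1 stands at the higher of the two numbers, but its gap to compound 2 lies within the usual scatter of repeated measurements, so the two cannot be told apart on the numbers alone.

Compound 3 `COc1cc(/C=C/C(=O)c2cccc(-n3cc(-c4ccc(Cl)cc4)[nH]c3=O)c2)ccc1O` has not yet been measured. It differs from compound 1 in a single place: chloro in place of hydrogen on an aromatic carbon. Among the measured compounds shown here, no measured pair shows this same change, so the data give no direct guide to its size or direction. For the measured compounds named here, with only two measured compounds, both sitting together, the expectation is that the step of a 1.2-fold lower number from compound 1 to compound 3 (0.09 log units; within the scatter) will be small and may well stay within the scatter, in either direction. Compound 3 is therefore expected to give about 1300 nM in this assay, with a range from 500 nM to 3500 nM.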

Compound 3, concentration for 50% growth inhibition: 1480 nM
Compound 3: the middle estimate sits 1.1-fold (0.06 log units) below what was measured; measured number inside the range.
By their numbers in this assay, from the lowest: compounds 2, 3 and 1 (each within the scatter of the next).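

Among the compounds shown here, compound 1 and compound 3 form the first pair here that differs in one place only: in this assay, going from phenyl to 4-chlorophenyl gives a 1.1-fold lower number from compound 1 to compound 3 (0.04 log units; within the scatter). A single chlorine atom on this aromatic carbon, para to a large group, therefore leaves the two compounds indistinguishable in this read-out, which is something that the comparison of compound 1 with compound 2 could not show, since those two differ in more than one place. No measurement at hand speaks to why the chloro compound behaves this way.

Going by these compounds, this one pair covers only chloro at this position, so it remains open whether a larger or very different group, such as an amine, a carboxylic acid or a longer chain like butyl, would also leave the number within the scatter or would move it clearly. On these data alone, it also remains open whether chloro on another carbon of the same ring would give a similar result, and whether the same change would behave alike in a compound with other substituents on the shared core.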